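Moving the indole attachment on the lead compound

The source may report more compounds than this note shows. Statements on the series, on what has been measured and on what is new or still open speak of the compounds shown alone.

Measured so far in a functional assay on MCF7 cells (Homo sapiens) for inhibition, read by CCK-8 assay, with a stated time of 48 h (a lower number here means a stronger inhibitor, a higher number a weaker inhibitor), on the shared core
- compound 1 `COc1cc(-c2ccnc3cc(-c4c[nH]c5ccccc45)nn23)cc(OC)c1OC` gives 85 nM
- compound 2 `COc1cc(-c2ccnc3cc(-c4ccccc4)nn23)cc(OC)c1OC` gives 254 nM
- compound 3 `COc1cc(-c2ccnc3cc(-c4ccc5c(ccn5C)c4)nn23)cc(OC)c1OC` gives 3 nM

Compound 3 has the lowest of the three numbers, and both of its gaps lie beyond the scatter (a 28-fold lower number from compound 1 to compound 3 (1.45 log units; beyond the scatter) and an 85-fold lower number from compound 2 to compound 3 (1.93 log units; beyond the scatter)). The next compound is compound 4 `COc1cc(-c2ccnc3cc(-c4ccc5ccn(C)c5c4)nn23)cc(OC)c1OC`, which has the same atoms as compound 3 joined differently: 1-methyl-1H-indol-6-yl in place of 1-methyl-1H-indol-5-yl on an aromatic carbon with 1-methyl-1H-indol-6-yl in place of 1-methyl-1H-indol-5-yl on an aromatic carbon.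

Within the data shown here, no measured step isolates this change. The closest is the step that brings in 1-methyl-1H-indol-5-yl in place of 1H-indol-3-yl (a 28-fold lower number from compound 1 to compound 3 (1.45 log units; beyond the scatter)), although it also differs in the methyl group. The replacement of phenyl by the same group is larger still (an 85-fold lower number from compound 2 to compound 3 (1.93 log units; beyond the scatter)), while the replacement of 1H-indol-3-yl by phenyl is modest (a 3.0-fold higher number from compound 1 to compound 2 (0.48 log units; beyond the scatter)). These steps show that the number can move widely at this carbon, but they do not fix a direction for compound 4. With compound 3 already the lowest value, a modest to large rise is expected in this assay, estimated as a 4.0-fold higher number from compound 3 to compound 4 (0.60 log units; beyond the scatter) here. Compound 4 is estimated at 12 nM with an expected range from 3 nM to 60 nM in this assay.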

Compound 4, half-maximal inhibitory concentration: 74 nM
Compound 4: the middle estimate sits 6.2-fold (0.79 log units) below what was measured; the measured number lies above the stated range.
By their numbers in this assay, from the lowest: compound 3; then compounds 4 and 1 (each within the scatter of the next); then compound 2.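

In this assay the point of attachment alone carries a large step, a 25-fold higher number from compound 3 to compound 4 (1.39 log units; beyond the scatter), with the group's atoms and counted features unchanged; each earlier step replaced one group with a different one, so none could separate this effect. The gain over phenyl falls to a 3.4-fold lower number from compound 2 to compound 4 (0.54 log units; beyond the scatter), and the comparison with the 1H-indol-3-yl group gives a 1.1-fold lower number from compound 1 to compound 4 (0.06 log units; within the scatter), which leaves compounds 1 and 4 level. Among these compounds, a methylated indole at this carbon is therefore not enough to reach the low number of compound 3 (3 nM), which depends on the 1-methyl-1H-indol-5-yl attachment; nothing at hand explains the gap between the two attachments.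

Still open, on these data alone, is how 1H-indol-5-yl, without the methyl group, would stand against compound 3, which would show how much of its low number goes with that methyl group. Also open, as far as these compounds go, is whether an ethyl group in place of that methyl, or a 1-methyl-1H-indol-4-yl group at the same carbon, would keep the number near that of compound 3 or move it towards that of compound 4.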